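A few compounds are considered here, and "the series" means these few. Any claim that something is new, unique, unknown or untested is made for them only; others in the source may bear on it.

In a functional assay on MCF7 cells (Homo sapiens) for inhibition, read by MTT assay, with a stated time of 3 days (a higher number here means a weaker inhibitor, a lower number a stronger inhibitor), the measured compounds read as follows:
compound 1 (`C/C=C/COc1cc(/C=C\c2cc(OC)c(OC)c(OC)c2)ccc1OC`) gives 5400 nM
compound 2 (`COCOc1cccc(/C=C/CCCOc2cc(/C=C\c3cc(OC)c(OC)c(OC)c3)ccc2OC)c1`) gives 8000 nM
compound 3 (`COCOc1ccc(/C=C/CCCOc2cc(/C=C\c3cc(OC)c(OC)c(OC)c3)ccc2OC)cc1`) gives 42000 nM

Compound 3 holds the highest of the three numbers, and compound 2 lies nearest to it. Compound 4 (`COc1ccc(/C=C\c2cc(OC)c(OC)c(OC)c2)cc1OCCC/C=C/c1ccc(Br)cc1`) has bromo in place of methoxymethoxy on an aromatic carbon, so that 4-(methoxymethoxy)phenyl becomes 4-bromophenyl. Among the measured compounds shown here, one measured step bears on this group: a 5.3-fold higher number from compound 2 to compound 3 (0.72 log units; beyond the scatter) when 4-(methoxymethoxy)phenyl replaces 3-(methoxymethoxy)phenyl. For the measured compounds named here, that step shows the number responding to a change in this group, but no measured compound carries bromo, so the evidence for the new group is thin. In this assay a step of similarly modest size is expected, and the direction is tentatively downward, given that compound 3 at 42000 nM already sits at the top of this small set. The expected change is a 2.8-fold lower number from compound 3 to compound 4 (0.45 log units; beyond the scatter) by this estimate. Compound 4 is estimated at 15000 nM with 5000 nM to 45000 nM as the expected range.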

Compound 4, half-maximal inhibitory concentration: 37000 nM
Compound 4: middle estimate off by 2.5-fold (0.39 log units), on the low side; low and high end bracket the measured number.
By their numbers in this assay, from the lowest: compounds 1 and 2 (each within the scatter of the next); then compounds 4 and 3 (each within the scatter of the next).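

In this assay, bromo in place of methoxymethoxy on this aromatic carbon, para to a large group, gives a 1.1-fold lower number from compound 3 to compound 4 (0.06 log units; within the scatter), so the two groups cannot be told apart here, although the earlier step, a 5.3-fold higher number from compound 2 to compound 3 (0.72 log units; beyond the scatter), showed the number responding to a change in the methoxymethoxy-bearing phenyl group. The gaps to the other two compounds, a 4.6-fold higher number from compound 2 to compound 4 (0.67 log units; beyond the scatter) and a 6.9-fold higher number from compound 1 to compound 4 (0.84 log units; beyond the scatter), remain beyond the scatter, so this exchange does not bring the number into line with either of them. No measured evidence accounts for these numbers.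

The compounds shown leave open what a quite different group on this aromatic carbon, such as an amine or a carboxylic acid, would do to the number. They also leave open whether the match between bromo and methoxymethoxy extends to any other group.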